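The source may report more compounds than this note shows. Statements on the series, on what has been measured and on what is new or still open speak of the compounds shown alone.

Measured so far in an ADME assay on MT4 cells (Homo sapiens) for cytotoxicity (on this read-out higher numbers stand for lower toxicity in this test and lower numbers for higher toxicity in this test), with each value a limit of the assay:

Compound 1 `Cc1cccc(S(=O)(=O)n2c(=O)[nH]c3ccc(Cl)cc32)c1` gives > 307000 nM as a limit
Compound 2 `Cc1ccc(C)c(S(=O)(=O)n2c(=O)[nH]c3ccc(Cl)cc32)c1` gives > 371000 nM as a limit
Compound 3 `Cc1ccc(S(=O)(=O)n2c(=O)[nH]c3ccc(Cl)cc32)cc1C` gives > 371000 nM as a limit

Compound 1 has no exact number and sits at the limit of > 307000 nM in this assay, at which 1 of the 3 values shown sits, on this scale. The other two compounds sit at the limit of > 371000 nM in this assay, at which 2 of the 3 values shown sit, and that is a limit too.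

Compound 4 `COc1cccc(S(=O)(=O)n2c(=O)[nH]c3ccc(Cl)cc32)c1` has not yet been measured. It differs from compound 1 by methoxy in place of methyl on an aromatic carbon and so carries methoxy in place of methyl on an aromatic carbon.

Within the data shown here, the nearest measured changes put methyl in place of hydrogen on an aromatic carbon, and no measured step swaps methyl for methoxy. Resting on a step that the two limits leave unreadable from compound 1 to compound 2 and on a step that the two limits leave unreadable from compound 1 to compound 3 as the only such steps, no shift beyond the usual scatter is expected in this assay and no direction is favoured. The expected step is an at least 1.0-fold lower number from compound 1 to compound 4 (0.02 log units; that floor lies within the scatter) in size. For compound 4 the estimate is 290000 nM with an expected range from 100000 nM to 400000 nM and the assay may well report only a limit again.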

Compound 4, half-maximal cytotoxic concentration: > 368000 nM
Compound 4: no number, only a limit; the forecaster's own chance of this, stated with the estimate: 85%; at least 1.2-fold (0.10 log units) between middle value and limit.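

In this assay compound 4 gives > 368000 nM, which is a limit and not a number. Compound 1 also has only a limit, so no step can be read between compound 1 and compound 4. The compounds shown leave open whether methoxy in place of methyl, or an added methyl, changes the result in this assay at all.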